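Removing the dichlorophenyl group from compound 1

A few compounds are considered here, and "the series" means these few. Any claim that something is new, unique, unknown or untested is made for them only; others in the source may bear on it.

Compound 1 (`O=C(NNc1ccnc2cc(Cl)ccc12)c1ccccc1/N=C/c1ccc(Cl)c(Cl)c1`) : 6.22
Compound 2 (`COc1cc(/C=N/c2ccccc2C(=O)NNc2ccnc3cc(Cl)ccc23)cc(OC)c1OC`) : 4.94

In a physicochemical assay for lipophilicity, measured as octanol-water partition (on this read-out higher numbers stand for higher lipophilicity and lower numbers for lower lipophilicity), compound 1 stands highest of the two measured compounds, and its gap to compound 2 lies beyond the usual scatter. Compound 3 (`O=C(NNc1ccnc2cc(Cl)ccc12)c1ccccc1/N=C/c1ccc(O)cc1`) has not yet been measured. It carries 4-hydroxyphenyl in place of 3,4-dichlorophenyl on a carbon with a double bond to nitrogen. For the measured compounds named here, no measured step covers this change, so its size cannot be read directly from the data. Going by the values given here, the only guide is that compound 2, which also lacks the 3,4-dichlorophenyl group, gives 4.94 and so lies lower than compound 1. In this assay the estimated change is a number 1.82 log units lower from compound 1 to compound 3 (beyond the scatter) and amounts to an expected fall beyond the scatter. Compound 3 is therefore estimated at 4.4 (range 3.8 to 5).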

Compound 3, partition coefficient: 4.65
For compound 3 the middle estimate is 0.25 log units below the measured one, and the stated range covers the measured number.
By their numbers in this assay, from the lowest: compounds 3 and 2 (each within the scatter of the next); then compound 1.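

In this assay, for the compounds shown here, the step of a number 1.57 log units lower from compound 1 to compound 3 (beyond the scatter) is the first direct reading at this position, where 4-hydroxyphenyl takes the place of 3,4-dichlorophenyl on a carbon with a double bond to nitrogen. It shows that, with the rest of compound 1 unchanged, this exchange alone moves the read-out by a large amount, beyond the scatter. Nothing at hand explains the size of this step.

The exchange removes both chlorine atoms and introduces the hydroxyl group together, so the compounds shown do not separate the contribution of either change. As far as these compounds go, whether a phenyl ring carrying a single chlorine, an amine or a carboxylic acid at this position would give a step of similar size remains open.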